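This account rests on a few compounds, and the source may have more. Where it says the series, first, only, none or still open, it means among the compounds named here.

Measured compounds and their inhibition in a functional assay on the whole organism with Rattus norvegicus as the target, at a dose of 20 mg/kg by the oral route; a lower number here means less inhibition, a higher number more inhibition at the dose given (going by the name of the read-out):
compound 1 `CC(C)NC(=O)/C=C1\CCc2ccc(F)cc21` gives 71%
compound 2 `NC(=O)/C=C1\CCc2cc(F)ccc21` gives 42%
compound 3 `CNC(=O)/C=C1\CCc2cc(Cl)ccc21` gives 44%

Compound 1 stands highest of the three numbers in this assay; its distance to compound 3 and to compound 2 is in each case beyond the usual scatter of repeated measurements. Compounds 2 and 3 sit close together, within that scatter of each other, so no order between them is read. Among the compounds with values here, each compound differs from the others in more than one place, so no single step between measured compounds can be isolated from these data.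

Compound 4 `O=C(/C=C1\CCc2ccc(F)cc21)NC1CC1` has not yet been measured in this assay. Against compound 1 the difference is cyclopropyl in place of isopropyl on an amide-type nitrogen, with the same number of heavy atoms leaving and entering, no change in donors, acceptors or charge, and the entering group a three-membered ring of carbon only. Within the data shown here, the series holds no measured pair that isolates a change on the amide-type nitrogen, so the expectation rests on compound 1 alone. The step from compound 1 to compound 4 is expected to be small, a number 6 percentage points lower from compound 1 to compound 4 (within the scatter), not clearly beyond the scatter in either direction. Compound 4 is thus estimated at 65%, within a range from 45% to 85%.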

Compound 4, a percentage reported as inhibition, in the whole organism at one dose (the size of the read-out at that dose, not a potency): 7%
Beside the measured number, compound 4's estimate is 58 percentage points above it, and the stated range ends above it.
By their numbers in this assay, from the lowest: compound 4; then compounds 2 and 3 (each within the scatter of the next); then compound 1.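

In this assay, within the data shown here, the step to the ring, cyclopropyl in place of isopropyl on an amide-type nitrogen, gives a number 64 percentage points lower from compound 1 to compound 4 (beyond the scatter), the first isolated change at this position. The change leaves the heavy-atom count, donors, acceptors and charge as they were, so these counts alone do not set the read-out here; the identity of the group on this nitrogen does, at least for this one pair. No measurement shown accounts for the size of this step.

On these data alone, whether cyclobutyl or a longer chain such as n-butyl on the same nitrogen of the core of compound 1 stays with compound 1 or falls towards compound 4 remains open. Compounds 2 and 3 differ from compound 1 in more than one place, so their steps cannot be read for this position.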